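Trimming One Methoxy Group from Compound 2

A few compounds are considered here, and "the series" means these few. Any claim that something is new, unique, unknown or untested is made for them only; others in the source may bear on it.

Among the three measured compounds, compound 2 `COc1cc(-c2cc(/C=C/C(=O)c3ccc(N)cc3)[nH]n2)cc(OC)c1OC` stands at the lowest number in a functional assay on HCT-116 cells (Homo sapiens) for cytotoxicity, read by sulforhodamine B assay, with a stated time of 48 h, tested at 10 uM (a lower number here means a stronger effect, a higher number a weaker effect of the compound at the concentration tested), where compound 2 gives -78%. Its nearest neighbour is compound 1 `COc1ccc(-c2cc(/C=C/C(=O)c3ccc(N)cc3)[nH]n2)cc1`, which in this assay gives -53%, a number above compound 2 by more than the scatter. The furthest is compound 3 `COc1cc(-c2cc(/C=C/C(=O)c3ccc(F)c(F)c3)[nH]n2)cc(OC)c1OC`, which in this assay gives 9%. Among the measured compounds shown here, the only measured step between compounds that differ in one place is a number 87 percentage points higher from compound 2 to compound 3 (beyond the scatter); it concerns the group on the carbonyl carbon and does not bear on the change considered here.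

Compound 4 `COc1ccc(-c2cc(/C=C/C(=O)c3ccc(N)cc3)[nH]n2)cc1OC` differs from compound 2 by hydrogen in place of methoxy on an aromatic carbon. For the measured compounds named here, no measured pair isolates this change. Compound 1 and compound 2 differ in two places, both methoxy groups, and their two values show compound 2 lower than compound 1 by a margin beyond the scatter. Compound 4 keeps one of the two methoxy groups that compound 1 lacks, so the expectation for compound 4 is placed between those two values, at -65%, with a range from -85% to -42%. This amounts to an expected step of a number 13 percentage points higher from compound 2 to compound 4 (beyond the scatter), which may well fall within the scatter.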

Compound 4, a percentage reported as activity, at one concentration (the size of the read-out at that concentration, not a potency): -73%
Beside the measured number, compound 4's estimate is 8 percentage points above it; low and high end bracket the measured number.
By their numbers in this assay, from the lowest: compounds 2 and 4 (each within the scatter of the next); then compound 1; then compound 3.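

In this assay, hydrogen in place of methoxy on this aromatic carbon, ortho to a methoxy group and meta to a large group, gives a number 5 percentage points higher from compound 2 to compound 4 (within the scatter), so compound 2 and compound 4 cannot be told apart at the concentration tested and this methoxy group makes no visible difference to the read-out. The opposite change, methoxy in place of hydrogen on an aromatic carbon, gives a number 20 percentage points lower from compound 1 to compound 4 (beyond the scatter), which shows that the same kind of change is not worth the same amount throughout this short series: it registers when compound 1 is the starting point and stays within the scatter when compound 4 is. Nothing available here explains why these two steps differ in size.

The compounds shown leave open whether a hydroxyl group, an ethoxy group or a chlorine atom on this carbon would give a read-out like that of compound 4 or would move it away. They also leave open whether hydrogen and methoxy remain interchangeable here with 3,4-difluorophenyl on the carbonyl carbon, as in compound 3, and whether compound 2 and compound 4 would still match at other concentrations.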